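Trifluoromethyl in place of bromo: what to expect

A few compounds are considered here, and "the series" means these few. Any claim that something is new, unique, unknown or untested is made for them only; others in the source may bear on it.

Compound 1 `COc1ccc(/C=C/C(=O)c2ccc(OC)c3c2OC(C)(C)C=C3)c(F)c1`: > 10000 nM (a limit)
Compound 2 `COc1ccc(C(=O)/C=C/c2ccc(Br)cc2)c2c1C=CC(C)(C)O2`: > 10000 nM (a limit)
Compound 3 `COc1ccc(C(=O)/C=C/c2cccc([N+](=O)[O-])c2)c2c1C=CC(C)(C)O2`: 5870 nM

These values come from a functional assay on K562 cells (Homo sapiens) for antiproliferative activity, read by MTT assay, with a stated time of 24 h; a lower number here means a stronger inhibitor, a higher number a weaker inhibitor. Compound 2 gives > 10000 nM, which is a limit and not a number. Compound 4 `COc1ccc(C(=O)/C=C/c2ccc(C(F)(F)F)cc2)c2c1C=CC(C)(C)O2` differs from it by trifluoromethyl in place of bromo on an aromatic carbon. Going by the values given here, no measured step makes this exact change. The nearest is an at least 1.7-fold lower number from compound 2 to compound 3 (0.23 log units; that floor lies within the scatter), which swaps the whole 4-bromophenyl for 3-nitrophenyl, and its floor lies within the scatter. The step that the two limits leave unreadable from compound 1 to compound 2 cannot be read. No step beyond the scatter is therefore expected in this assay, and another limit is quite possible. The estimated step is a step that the limit leaves unreadable from compound 2 to compound 4. The expected value for compound 4 is 12000 nM, with an estimated range of 5000 nM to 30000 nM.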

Compound 4, half-maximal inhibitory concentration: > 10000 nM
Compound 4: only a limit was reported (the forecaster's own chance of this, stated with the estimate: 65%); the middle value does not contradict the limit.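

In this assay, going by these compounds alone, compound 2 and compound 4 each give only a limit and not a number, and no step between them can be read. Both stand at the same limit: the limit of > 10000 nM in this assay, at which 3 of the 4 values shown sit. On these data alone, whether trifluoromethyl in place of bromo changes the activity at all stays open.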